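Aryl swap from compound 3 to compound 4

This account rests on a few compounds, and the source may have more. Where it says the series, first, only, none or still open, it means among the compounds named here.

All compounds share one core and differ in the aryl group on a saturated chain carbon bound to a nitrogen on an aromatic ring. In a functional assay on HL-60 cells (Homo sapiens) for antiproliferative activity, with a stated time of 72 h (on this read-out lower numbers stand for stronger inhibition and higher numbers for weaker inhibition), compound 1 `OC[C@H]1O[C@@H](n2cnc3c(NCc4cccc(F)c4)ncnc32)[C@H](O)[C@@H]1O` gives 920 nM and compound 2 `OC[C@H]1O[C@@H](n2cnc3c(NCc4ccccc4Cl)ncnc32)[C@H](O)[C@@H]1O` gives 1600 nM, with a 1.7-fold higher number from compound 1 to compound 2 (0.24 log units; within the scatter). In this assay, compound 3 `COc1ccccc1CNc1ncnc2c1ncn2[C@@H]1O[C@H](CO)[C@@H](O)[C@H]1O` gives 2300 nM. It sits at the weak end of this small set, though it cannot be separated from compound 2, as a 1.4-fold higher number from compound 2 to compound 3 (0.16 log units; within the scatter) shows. Only a 2.5-fold higher number from compound 1 to compound 3 (0.40 log units; beyond the scatter) is a modest step that clears the scatter.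

Next is compound 4 `COc1cc(CNc2ncnc3c2ncn3[C@@H]2O[C@H](CO)[C@@H](O)[C@H]2O)cc(OC)c1`, with 3,5-dimethoxyphenyl in place of 2-methoxyphenyl on a saturated chain carbon bound to a nitrogen on an aromatic ring. Within the data shown here, no measured compound carries 3,5-dimethoxyphenyl, so the evidence is indirect. The nearest guide is a 2.5-fold higher number from compound 1 to compound 3 (0.40 log units; beyond the scatter), which links 3-fluorophenyl to 2-methoxyphenyl, and it is small. The other two steps stay within the scatter. Across these three compounds, the aryl changes move the number only slightly, so no step beyond the scatter is expected in this assay, with at most a slight lean towards a lower number. The expected change is a 1.2-fold lower number from compound 3 to compound 4 (0.08 log units; within the scatter). For compound 4 the estimated value is 1900 nM, with an expected range of 700 nM to 5500 nM.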

Compound 4, half-maximal inhibitory concentration: 20200 nM
Compound 4: middle estimate off by 11-fold (1.03 log units), on the low side; measured number outside the range, above it.
By their numbers in this assay, from the lowest: compounds 1, 2 and 3 (each within the scatter of the next, the first and the last beyond it); then compound 4.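

In this assay, the aryl group on a saturated chain carbon bound to a nitrogen on an aromatic ring can move the number well beyond the scatter, which the small differences among compounds 1, 2 and 3 gave no sign of: the step is an 8.8-fold higher number from compound 3 to compound 4 (0.94 log units; beyond the scatter) and grows to a 13-fold higher number from compound 2 to compound 4 (1.10 log units; beyond the scatter) and further to a 22-fold higher number from compound 1 to compound 4 (1.34 log units; beyond the scatter) against the other two aryl groups. Among these compounds, compound 4 is the only one of the four with 3,5-dimethoxyphenyl, and its single aryl change from compound 3 alters both the number of methoxy groups and where they stand, so the two alterations cannot be told apart here. No available measurement bears on the cause of this loss of inhibition.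

Whether a single methoxy group in another place or the second methoxy group accounts for the step stays open, and 3-methoxyphenyl on the shared core would help separate the two. As far as these compounds go, it is also open whether the step follows from the substitution pattern of 3,5-dimethoxyphenyl itself, which other aryl groups substituted in the same places could test.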